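Thiazolyl-anilines on RKO cells: methoxyphenyl for bromophenyl

The source may report more compounds than this note shows. Statements on the series, on what has been measured and on what is new or still open speak of the compounds shown alone.

Measured so far in a functional assay on RKO cells (Homo sapiens) for cytotoxicity, read by resazurin assay, with a stated time of 72 h; on this read-out higher numbers stand for weaker inhibition and lower numbers for stronger inhibition:
- compound 1, `COc1ccc(Nc2nc(-n3cnc4ccccc43)cs2)cc1`: > 100000 nM
- compound 2, `Cc1nc2ccccc2n1-c1csc(Nc2ccc(S(N)(=O)=O)cc2)n1`: 45000 nM
- compound 3, `Cc1nc2ccccc2n1-c1csc(Nc2cccc(Br)c2)n1`: 36000 nM

The value of compound 1 in this assay is a limit of the assay, not a number. Two numbers remain. Compound 3 gives 36000 nM and compound 2 gives 45000 nM; these two sit within the usual scatter of each other, so neither can be set apart from the other. For the measured compounds named here, compound 3 thus stands among weak inhibitors, and nothing so far reaches lower.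

The next compound is compound 4, `COc1ccc(Nc2nc(-n3c(C)nc4ccccc43)cs2)cc1`, not yet measured in this assay. Against compound 3 the change is 4-methoxyphenyl in place of 3-bromophenyl on a nitrogen on an aromatic ring. Going by the values given here, no measured pair in this set isolates this exchange, so no measured step can be pointed to for its size.

The expectation for compound 4 is a step towards weaker inhibition of about a 2.2-fold higher number from compound 3 to compound 4 (0.35 log units; beyond the scatter), a size at the edge of the scatter rather than clearly beyond it. The estimate for compound 4 in this assay is 80000 nM, with a range from 30000 nM to 200000 nM, and a real chance that only a limit is reported.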

Compound 4, half-maximal inhibitory concentration: 25 nM
Compound 4: middle estimate off by 3200-fold (3.51 log units), on the high side, outside the stated range (below it).
By their numbers in this assay, from the lowest: compound 4; then compounds 3 and 2 (each within the scatter of the next). At a limit, above all of these: compound 1.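

In this assay, compounds 2 and 3 gave no sign that the group on the aniline nitrogen could matter much, yet 4-methoxyphenyl in place of 3-bromophenyl on this nitrogen gives a 1400-fold lower number from compound 3 to compound 4 (3.16 log units; beyond the scatter), and methoxy in place of sulfamoyl on an aromatic carbon gives a 1800-fold lower number from compound 2 to compound 4 (3.26 log units; beyond the scatter). The methyl on the core matters just as much: methyl in place of hydrogen on an aromatic carbon, with the 4-methoxyphenyl kept, gives an at least 4000-fold lower number from compound 1 to compound 4 (3.60 log units; beyond the scatter), so among the compounds shown only the one carrying both the methyl and the 4-methoxyphenyl reaches the low range. The size of that last step is open-ended, as compound 1 stands at a limit of the assay and not at a number: the limit of > 100000 nM in this assay, at which 1 of the 4 values shown sits.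

The exchange from compound 3 alters both the substituent and its place on the phenyl ring, so the compounds shown do not separate the methoxy group itself from where it sits. Also open, as far as these compounds go, is how narrow the requirement is at either site, for instance with an ethyl in place of the methyl on the core or an amine in place of the methoxy.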